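The source may report more compounds than this note shows. Statements on the series, on what has been measured and on what is new or still open speak of the compounds shown alone.

Compound 1 `Cn1c(=O)c(S(=O)(=O)c2ccc(F)cc2F)cc2cnc(Nc3ccc4[nH]ncc4c3)nc21` gives the highest number of the three compounds measured in a functional assay on K562 cells (Homo sapiens) for inhibition, read by trypan blue exclusion, with a stated time of 72 h (a lower number here means a stronger inhibitor, a higher number a weaker inhibitor), at 50000 nM. Compound 2 `Cn1c(=O)c(S(=O)(=O)c2ccc(F)cc2)cc2cnc(Nc3ccc4[nH]ncc4c3)nc21` gives 10000 nM, and compound 3 `COC(=O)Cn1ccc2cc(Nc3ncc4cc(S(=O)(=O)c5ccc(F)cc5F)c(=O)n(C)c4n3)ccc21` gives 5000 nM. Compound 4 `Cc1cc2cc(Nc3ncc4cc(S(=O)(=O)c5ccc(F)cc5F)c(=O)n(C)c4n3)ccc2[nH]1` has not yet been measured. It differs from compound 1 in one place: 2-methyl-1H-indol-5-yl in place of 1H-indazol-5-yl on a nitrogen on an aromatic ring. Among the measured compounds shown here, the only measured step, a 5.0-fold lower number from compound 1 to compound 2 (0.70 log units; beyond the scatter), changes a different part of the molecule and so does not speak directly to this change. Compound 3 also lacks the group that leaves in this change, and compound 3 gives 5000 nM, well under the number for compound 1, which hints that the replacement is at least tolerated. Compound 4 is therefore expected to give a lower number, a 5.0-fold lower number from compound 1 to compound 4 (0.70 log units; beyond the scatter). The estimate for compound 4 is 10000 nM, ranging from 2500 nM to 40000 nM.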

Compound 4, half-maximal inhibitory concentration: 750 nM
Estimate against measurement, compound 4: 13-fold (1.12 log units) above; the measured number lies below the stated range.
By their numbers in this assay, from the lowest: compound 4; then compounds 3 and 2 (each within the scatter of the next); then compound 1.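

In this assay, the change on this nitrogen gives a 67-fold lower number from compound 1 to compound 4 (1.82 log units; beyond the scatter), so the group held here has a large effect on the number, well beyond merely being tolerated. The change alters two things at once, replacing a ring nitrogen with carbon and adding a methyl group. Nothing available explains the step.

The compounds shown do not separate those two alterations, so it remains open how an unsubstituted 1H-indol-5-yl would behave. Going by these compounds, how an amine or a carboxylic acid on this ring would behave also remains open.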